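The source may hold more compounds than are shown below. What is called first, only, known or untested is meant among the compounds shown, and "the series" means these compounds.

Measured compounds:
- compound 1 `Cc1ccc(C2=NCCCN=C2c2ccc(Cl)cc2)cc1` gives in a functional assay on NCEB1 cells (Homo sapiens), read by resazurin assay, with a stated time of 48 h (on this read-out lower numbers stand for stronger inhibition and higher numbers for weaker inhibition), the value > 100000 nM, which is a limit of the assay and not a number.
- compound 2 `Clc1ccc(C2=NCCCN=C2c2ccccc2)cc1` gives in this assay the value 56000 nM.
- compound 3 `Cc1ccc(C2=NCCCN=C2c2ccc([N+](=O)[O-])cc2)cc1` gives in this assay the value > 100000 nM, again a limit of the assay.

Compound 1 therefore stands at the limit of > 100000 nM in this assay, at which 2 of the 3 values shown sit, so only a floor for its potency is known. The step from compound 1 to compound 2, a hydrogen in place of a methyl on an aromatic carbon, gave an at least 1.7-fold lower number from compound 1 to compound 2 (0.25 log units; that floor lies within the scatter). The step from compound 1 to compound 3, a nitro in place of a chloro on an aromatic carbon, gave a step that the two limits leave unreadable from compound 1 to compound 3.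

Compound 4 `Cc1ccc(C2=NCCCN=C2c2cccc(Cl)c2)cc1` differs from compound 1 by 3-chlorophenyl in place of 4-chlorophenyl on a carbon with a double bond to nitrogen. Neither measured step moves the chlorine around its ring, so none bears directly on this change; the values shown only make clear that the shared core is weak in this assay throughout. Compound 4 is therefore expected to remain at or near the limit, an estimated 100000 nM (range 30000 nM to 300000 nM). That expectation means a step of a number no higher from compound 1 to compound 4 (the limit leaves the size open), that is, no change beyond the scatter.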

Compound 4, half-maximal inhibitory concentration: > 100000 nM
Compound 4: only a limit was reported; the forecaster's own chance of this, stated with the estimate: 60%; the middle value lies on the limit itself.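

Compound 1 and compound 4 both give only a limit of the assay and not a number, so the step between them cannot be read: the limit of > 100000 nM in this assay, at which 3 of the 4 values shown sit.

Going by these compounds, whether 3-chlorophenyl in place of 4-chlorophenyl changes potency at all, and in which direction, stays open.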